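Swapping the nitrogen substituent of compound 3

The source may hold more compounds than are shown below. What is called first, only, known or untested is meant among the compounds shown, and "the series" means these compounds.

Measured so far in a functional assay on DU-145 cells (Homo sapiens) for cytotoxicity, read by trypan blue exclusion, with a stated time of 96 h (on this read-out lower numbers stand for stronger inhibition and higher numbers for weaker inhibition), for three compounds:
- compound 1 `COc1ccc(/C=C/S(=O)(=O)Cc2ccc(OC)c(N)c2)cc1` gives 2500 nM
- compound 2 `COc1cc(OC)c(/C=C/S(=O)(=O)Cc2ccc(Br)c(N)c2)c(OC)c1` gives 750 nM
- compound 3 `COC(=O)[C@H](C)Nc1cc(CS(=O)(=O)/C=C/c2c(OC)cc(OC)cc2OC)ccc1OC` gives 750 nM

Compound 3 sits at 750 nM and compound 2 at 750 nM with no difference at the digits shown, so the two lie within the scatter of each other and together hold the lowest number of the three. Compound 1 at 2500 nM stands on the higher side of both, beyond the scatter.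

Going by the values given here, the next compound to be tested is compound 4 `COC(=O)C(Nc1cc(CS(=O)(=O)/C=C/c2c(OC)cc(OC)cc2OC)ccc1OC)c1ccc(Cl)cc1` and it has (4-chlorophenyl)(methoxycarbonyl)methyl in place of 1-(methoxycarbonyl)ethyl on a nitrogen on an aromatic ring as its one change from compound 3. Among the compounds with values here, no pair of measured compounds differs in a single place, so nothing measured yet shows what this swap does. The expectation therefore starts from compound 3 at 750 nM and allows for a small shift toward weaker inhibition. The expected change is a 1.3-fold higher number from compound 3 to compound 4 (0.12 log units; within the scatter) and would stay within the scatter, though a larger move cannot be ruled out. In this assay compound 4 is estimated at 1000 nM with a range from 300 nM to 3500 nM as the expected span of a measurement.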

Compound 4, half-maximal inhibitory concentration: 400 nM
The estimate for compound 4 lay 2.5-fold (0.40 log units) above the measured number; the measured number falls inside the stated range.
By their numbers in this assay, from the lowest: compounds 4, 2 and 3 (each within the scatter of the next); then compound 1.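

Going by these compounds alone, at the nitrogen on an aromatic ring, the first readable step in this assay replaces 1-(methoxycarbonyl)ethyl with (4-chlorophenyl)(methoxycarbonyl)methyl and gives a 1.9-fold lower number from compound 3 to compound 4 (0.27 log units; within the scatter), a move that stays within the usual scatter. The entering group has 12 heavy atoms against 6 in the group it replaces, brings a six-membered aromatic ring and a chlorine, and has no defined stereocentre, yet the read-out does not shift beyond the scatter, so this place accepts a much larger substituent carrying an aromatic ring without a measurable loss. No supporting data are available to explain this outcome.

Because the ring, the chlorine and the loss of the defined stereocentre all arrive in one step, the compounds shown cannot assign any part of the outcome to any one of these features, and a plain phenyl without the chlorine would be needed to begin separating them. They also leave open how this position would read with a carboxylic acid in place of the methoxycarbonyl group, or with a longer chain between the nitrogen and the aromatic ring.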